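The source may hold more compounds than are shown below. What is called first, only, known or untested is meant among the compounds shown, and "the series" means these compounds.

Of the compounds shown here, three carrying a 1H-imidazol-1-yl group have been measured in a functional assay on DU-145 cells (Homo sapiens) for cytotoxicity, read by sulforhodamine B assay, with a stated time of 72 h; a higher number here means a weaker inhibitor, a lower number a stronger inhibitor. Compound 1 (`Brc1cccc(OCCCCn2ccnc2)c1`) gives 46600 nM, compound 2 (`Ic1ccc(OCCCCCn2ccnc2)cc1`) gives 27700 nM, and compound 3 (`c1ccc2sc(SCCCn3ccnc3)nc2c1`) gives 54800 nM. Compound 3 therefore stands within the usual scatter of both compound 1 and compound 2, and the three values do not separate.

Compound 4 (`c1ccc2sc(SCCCCn3ccnc3)nc2c1`) differs from compound 3 in one place: (1H-imidazol-1-yl)methyl in place of 1H-imidazol-1-yl on a saturated chain carbon, three bonds along the chain from a sulfur. This puts (1H-imidazol-1-yl)methyl in place of 1H-imidazol-1-yl on a saturated chain carbon, three bonds along the chain from a sulfur.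

Among the measured compounds shown here, no two measured compounds differ in only one place, so no measured step speaks directly to this change. With compound 3 at 54800 nM and compound 2 at 27700 nM still inside the scatter despite their different structures, no change beyond the scatter is expected in this assay. The estimated 1.3-fold lower number from compound 3 to compound 4 (0.12 log units; within the scatter) is a small move toward a lower number. For compound 4 the expected value is 42000 nM, with an estimated range of 20000 nM to 85000 nM.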

Compound 4, half-maximal inhibitory concentration: 82200 nM
The estimate for compound 4 lay 2.0-fold (0.29 log units) below the measured number; the range from low to high includes it.
By their numbers in this assay, from the lowest: compounds 2, 1, 3 and 4 (each within the scatter of the next, the first and the last beyond it).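

Among the compounds shown here, compound 3 and compound 4 give the first direct reading at this position, a saturated chain carbon, three bonds along the chain from a sulfur. In this assay, putting (1H-imidazol-1-yl)methyl in place of 1H-imidazol-1-yl gives a 1.5-fold higher number from compound 3 to compound 4 (0.18 log units; within the scatter), so this single change does not separate the pair, and the position tolerates the exchange without a measurable shift in this read-out. Nothing available speaks to the reason for this outcome.

The compounds shown leave open whether a longer chain at this position would move the number beyond the scatter, since this one step covers only a single exchange. They also leave open whether an amine or a carboxylic acid in place of the 1H-imidazol-1-yl group would keep the number where it stands.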